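Opening an amine-nitrogen aryl change on the shared core

The compounds below may be only part of what the source reports. "The series", "measured", "known", "first", "only" and "open" are said of these compounds alone.

Going by the values given here, compound 1 `Cc1nc(-c2ccccc2)c(C(=O)N2CCN(c3c(C)cccc3C)CC2)o1` sits at the weaker end of the two numbers measured so far. In a functional assay on HL-60 cells (Homo sapiens) for inhibition, read by MTT assay, with a stated time of 72 h (a lower number here means a stronger inhibitor, a higher number a weaker inhibitor), compound 1 gives 146 nM. Compound 2 `Cc1nc(-c2cccc(F)c2)c(C(=O)N2CCN(c3cc(Cl)cc(Cl)c3)CC2)o1` gives 41.7 nM in this assay, a stronger result than compound 1 by a gap that goes beyond the scatter. Compound 3 `Cc1nc(-c2ccc(F)cc2)c(C(=O)N2CCN(c3ccc(Cl)cc3)CC2)o1` is reported in this assay as "not active" (no number reported), with no number attached.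

Compound 4 `COc1cccc(N2CCN(C(=O)c3oc(C)nc3-c3ccccc3)CC2)c1` has not yet been measured in this assay. It differs from compound 1 in one place: 3-methoxyphenyl in place of 2,6-dimethylphenyl on an amine nitrogen in a ring. Among the compounds with values here, no measured pair in the set isolates a change of this kind, so the size and direction of the step can only be guessed. Compound 2 shows that a different aryl group on that ring nitrogen can bring a stronger number than compound 1, while compound 3 shows that another choice can lose activity altogether; compound 4 is expected to land near compound 1, with a step of a 1.2-fold lower number from compound 1 to compound 4 (0.09 log units; within the scatter) that may well lie within the scatter. The estimate for compound 4 is 120 nM, within a range from 35 nM to 450 nM.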

Compound 4, half-maximal inhibitory concentration: 34.8 nM
For compound 4 the middle estimate is 3.4-fold (0.54 log units) above the measured one; measured number outside the range, below it.
By their numbers in this assay, from the lowest: compounds 4 and 2 (each within the scatter of the next); then compound 1.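

Going by these compounds alone, the step of a 4.2-fold lower number from compound 1 to compound 4 (0.62 log units; beyond the scatter) is the first measured one at this position, and it shows that changing only the aryl group on the amine nitrogen in a ring can move the number in this assay beyond the scatter. Within this pair, 3-methoxyphenyl, which carries one hydrogen-bond acceptor where 2,6-dimethylphenyl carries none, gives the stronger inhibitor while the rest of the molecule stays the same. Nothing measured here accounts for the size or the direction of this step.

On these data alone, whether the gain belongs to the methoxy group or to the departure of the two methyl groups stays open, and a plain phenyl group on that nitrogen would help separate the two. As far as these compounds go, how a hydroxyl group or an amine in place of the methoxy group would read in this assay is also open.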